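The compounds below may be only part of what the source reports. "The series", "measured", "known", "first", "only" and "open" are said of these compounds alone.

Measured compounds:
Compound 1, `CC(=O)OC[C@H]1O[C@@H](n2cc(-c3cc(-c4ccc(C(C)(C)C)cc4)no3)c(=O)[nH]c2=O)C[C@@H]1OC(C)=O`, 112%
Compound 2, `CC(=O)OC[C@H]1O[C@@H](n2cc(-c3cc(-c4ccccc4)no3)c(=O)[nH]c2=O)C[C@@H]1OC(C)=O`, 91.4%
Compound 3, `CC(C)(C)c1ccc(Cn2cc(-c3cn([C@H]4C[C@H](O)[C@@H](CO)O4)c(=O)[nH]c3=O)nn2)cc1`, 95%

All three were tested in a functional assay on NCI-H23 cells (Homo sapiens) for cytotoxicity, read by sulforhodamine B assay, tested at 10 uM; on this read-out lower numbers stand for less inhibition and higher numbers for more inhibition at the one concentration tested (going by the name of the read-out). Compound 1 gives 112%, compound 2 gives 91.4%, and compound 3 gives 95%. Compounds 1 and 2 share one core and differ in a single spot: hydrogen in place of tert-butyl on an aromatic carbon. That change gave a number 20.6 percentage points lower from compound 1 to compound 2 (beyond the scatter). Compound 3 is built on a different core; the difference between the two cores is not broken down here. The values of compound 3 and compound 2 lie within the scatter of each other, while compound 1 stands beyond the scatter higher than compound 3.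

Compound 4, `O=c1[nH]c(=O)n([C@H]2C[C@H](O)[C@@H](CO)O2)cc1-c1cn(Cc2ccccc2)nn1`, has not yet been measured in this assay . It differs from compound 3 in one place: hydrogen in place of tert-butyl on an aromatic carbon. Within the data shown here, this is the same change as the one between compound 1 and compound 2, at the same kind of place on both cores: an aromatic carbon of a six-membered aromatic ring of carbon only, para to a large group.

Because the change gave a number 20.6 percentage points lower from compound 1 to compound 2 (beyond the scatter) on the core of compound 1, a lowering is also expected here, though with a different core the size is uncertain, so for compound 4 the expected step is a number 15 percentage points lower from compound 3 to compound 4 (beyond the scatter). The estimate for compound 4 is 80%, expected to fall between 60% and 100%.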

Compound 4, a percentage reported as inhibition, at one concentration (the size of the read-out at that concentration, not a potency): 97.5%
For compound 4 the middle estimate is 17.5 percentage points below the measured one, and the stated range covers the measured number.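

In this assay, putting hydrogen in place of tert-butyl gives a number 2.5 percentage points higher from compound 3 to compound 4 (within the scatter), so the lowering seen on the core of compound 1 does not reappear on the core of compound 3, and the two steps differ: the same change on two cores in this assay, a number 20.6 percentage points lower (beyond the scatter) from compound 1 to compound 2 and a number 2.5 percentage points higher (within the scatter) from compound 3 to compound 4, 23.1 percentage points apart, beyond the scatter of two such steps In these two pairs, then, the outcome of this change depends on the core it is made on, and a step measured on one core is a poor guide to the step on the other. This does not show why the two cores part ways, and two pairs say nothing about other changes or other cores; each number is also a read-out at one concentration, not a potency.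

The compounds shown leave open whether a different group at the same place on the ring, such as an amine, a carboxylic acid or a methoxy group, would give a clear step on either core. Also open, going by these compounds, is which part of the core matters, for instance whether the step on the core of compound 1 would survive with free hydroxyl groups in place of its acetate esters.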